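The compounds below may be only part of what the source reports. "The series", "measured", "known", "first", "only" and "open" are said of these compounds alone.

Measured so far in an assay on isolated protein for agonist activity at Bile acid receptor (Homo sapiens), read by AlphaScreen, with a stated time of 30 min; on this read-out lower numbers stand for smaller maximal responses and higher numbers for larger maximal responses:

compound 1, `COc1ccccc1-n1nc(C)c2c1NC(=O)[C@H](C)S[C@@H]2c1ccc(Oc2ccccc2)cc1`: 37%
compound 2, `Cc1ccccc1-n1nc(C)c2c1NC(=O)[C@H](C)S[C@@H]2c1ccc(-c2ccsc2)cc1`: 68%
compound 3, `Cc1nn(-c2ccccc2C(C)C)c2c1[C@@H](c1ccc(Oc3ccccc3)cc1)S[C@@H](C)C(=O)N2`: 174%

Compound 2 stands second highest of these three numbers in this assay. Its nearest neighbour is compound 1, whose value of 37% lies beyond the scatter below it; the furthest is compound 3, whose value of 174% lies far above it, also beyond the scatter. Compound 4, `COc1cccc(Oc2ccc([C@H]3S[C@@H](C)C(=O)Nc4c3c(C)nn4-c3ccccc3C)cc2)c1`, has not yet been measured in this assay. It differs from compound 2 in one place: 3-methoxyphenoxy in place of thiophen-3-yl on an aromatic carbon.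

Among the compounds with values here, the only single-place step measured, a number 137 percentage points higher from compound 1 to compound 3 (beyond the scatter), concerns a different position of the shared core, so it does not bear directly on the change made in compound 4. Compounds 1 and 3 both carry a phenoxy group at the position that is changed here and reach very different values, which shows that this position does not by itself fix the response. Within the data shown here, no measured pair isolates the group that is exchanged here.

Compound 4 is therefore expected to lie close to compound 2, with a step of a number 8 percentage points lower from compound 2 to compound 4 (within the scatter) that may well fall within the scatter. The estimated value of compound 4 is 60%, in a range from 25% to 110%.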

Compound 4, largest response reached (reported as efficacy), in percent of the reference or control that the assay uses: 120%
Estimate against measurement, compound 4: 60 percentage points below; the whole stated range lies below it.
By their numbers in this assay, from the lowest: compound 1; then compound 2; then compound 4; then compound 3.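

In this assay, the exchange of thiophen-3-yl for 3-methoxyphenoxy gives a number 52 percentage points higher from compound 2 to compound 4 (beyond the scatter), and this is the first pair shown in which only the group at this position changes. Within the data shown here, the earlier compounds showed only that compound 1 and compound 3, both with phenoxy here, could differ widely through a change elsewhere; this step shows that, with the rest of the molecule held constant, the group on this aromatic carbon, para to a large group, can itself shift the maximal response by a large amount. The entering group is larger, with 9 heavy atoms against 5, and replaces a five-membered aromatic ring holding sulfur with a six-membered aromatic ring of carbon only, so several things change together in this single step.

The compounds shown leave open which part of 3-methoxyphenoxy goes with the higher response, whether the methoxy, the ether oxygen or the six-membered ring, and how an amine or a carboxylic acid in its place would read. No evidence is available on what lies behind this step.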